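This account rests on a few compounds, and the source may have more. Where it says the series, first, only, none or still open, it means among the compounds named here.

Series notes. Compound 1 `COc1ccc2c(=O)c(/C=C/C(=O)NCc3cccc(F)c3)coc2c1` and compound 2 `CCOc1ccc(NC(=O)/C=C/c2coc3cc(OC)ccc3c2=O)cc1` share one core and differ only on the amide-type nitrogen. In a functional assay on Huh-7 cells (Homo sapiens) for inhibition, read by MTT assay, with a stated time of 48 h (on this read-out lower numbers stand for stronger inhibition and higher numbers for weaker inhibition), compound 1 gives 10100 nM, while in this assay compound 2 gives 3230 nM. Among the compounds with values here, the single measured step, a 3.1-fold lower number from compound 1 to compound 2 (0.50 log units; beyond the scatter), is modest and leaves compound 2 with the lowest of the two numbers so far.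

Compound 3 `COc1ccc2c(=O)c(/C=C/C(=O)Nc3cccc(C)c3)coc2c1` is the next variation: 3-methylphenyl in place of 4-ethoxyphenyl on an amide-type nitrogen. Within the data shown here, the step from compound 1 to compound 2 bears on it only in part: compound 2 and compound 3 both carry a six-membered aromatic ring of carbon only on the amide-type nitrogen, so the gain seen in that step is presumed kept, but no measured pair separates 4-ethoxyphenyl from 3-methylphenyl. In this assay a step of a 1.5-fold higher number from compound 2 to compound 3 (0.19 log units; within the scatter) is expected, towards a somewhat higher number or none beyond the scatter. Compound 3 is therefore estimated at 5000 nM, with a range from 2000 nM to 13000 nM.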

Compound 3, half-maximal inhibitory concentration: 15500 nM
Beside the measured number, compound 3's estimate is 3.1-fold (0.49 log units) below it; the measured number lies above the stated range.
By their numbers in this assay, from the lowest: compound 2; then compounds 1 and 3 (each within the scatter of the next).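

In this assay, the two aryl groups on the amide-type nitrogen are not interchangeable, as a 4.8-fold higher number from compound 2 to compound 3 (0.68 log units; beyond the scatter) shows, even though 4-ethoxyphenyl and 3-methylphenyl each bring one six-membered aromatic ring of carbon only. A ring of that kind at this place is therefore not enough for the lower number of compound 2, and compound 3 goes against any such reading: a 1.5-fold higher number from compound 1 to compound 3 (0.19 log units; within the scatter) shows that 3-methylphenyl in place of 3-fluorobenzyl gives no change beyond the scatter. Nothing on hand accounts for the difference between these groups.

The two aryl groups differ in both substituent and ring location, so 4-methylphenyl and 3-ethoxyphenyl on the amide-type nitrogen would be needed to separate these two changes. Going by these compounds, how an amine or a carboxylic acid on that ring would read also remains open.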